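The source may report more compounds than this note shows. Statements on the series, on what has been measured and on what is new or still open speak of the compounds shown alone.

Measured in an ADME assay on MT4 cells (Homo sapiens) for cytotoxicity, read by MTT assay (on this read-out lower numbers stand for higher toxicity in this test and higher numbers for lower toxicity in this test), so far:
compound 1 (`Cc1cc(C)cc(S(=O)(=O)c2c(C(=O)NCc3ccccc3)[nH]c3ccc(Cl)cc23)c1`): 38000 nM
compound 2 (`Cc1cc(C)cc(S(=O)(=O)c2c(C(=O)NC(C)c3cccnc3)[nH]c3ccc(Cl)cc23)c1`): 54600 nM

Within the data shown here, compound 2 stands at 54600 nM and cannot be told apart from the only other measured compound, the step between them being a 1.4-fold higher number from compound 1 to compound 2 (0.16 log units; within the scatter) and no more. The unmeasured compound 3 (`Cc1cc(C)cc(S(=O)(=O)c2c(C(=O)NNc3ccncc3)[nH]c3ccc(Cl)cc23)c1`) differs from compound 2 at the amide-type nitrogen: (pyridin-4-yl)amino in place of 1-(pyridin-3-yl)ethyl on an amide-type nitrogen and thus (pyridin-4-yl)amino stands in place of 1-(pyridin-3-yl)ethyl on an amide-type nitrogen. Among the measured compounds shown here, one measured step bears on this change, at that same kind of nitrogen: a 1.4-fold higher number from compound 1 to compound 2 (0.16 log units; within the scatter) for 1-(pyridin-3-yl)ethyl in place of benzyl. For the measured compounds named here, no measured compound carries (pyridin-4-yl)amino, so that single step is thin evidence. Resting on it, no step beyond the scatter is expected in this assay and no firm direction can be given. The expected step is a 1.4-fold lower number from compound 2 to compound 3 (0.14 log units; within the scatter) as an estimate only. For compound 3 the estimated value is 40000 nM with an expected range from 10000 nM to 120000 nM around it.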

Compound 3, half-maximal cytotoxic concentration: 30300 nM
For compound 3 the middle estimate is 1.3-fold (0.12 log units) above the measured one; the measured number falls inside the stated range.
By their numbers in this assay, from the lowest: compounds 3, 1 and 2 (each within the scatter of the next).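

Replacing 1-(pyridin-3-yl)ethyl with (pyridin-4-yl)amino on the amide-type nitrogen, which brings in a hydrogen-bond donor that the departing group lacks, gives a 1.8-fold lower number from compound 2 to compound 3 (0.26 log units; within the scatter) in this assay. Measured against the benzyl group, the same (pyridin-4-yl)amino gives a 1.3-fold lower number from compound 1 to compound 3 (0.10 log units; within the scatter), so three different groups at this nitrogen now stand within the scatter of one another, and this assay does not separate them. Adding a hydrogen-bond donor at this place therefore leaves no readable mark on the number, and no measurement is at hand that would explain these values.

All three groups on the amide-type nitrogen carry a six-membered aromatic ring, so the compounds leave open whether a group without such a ring, such as a morpholine or a plain ethyl chain, would move the number beyond the scatter. They also leave open how the number would respond to a change on the shared core, for example an amine in place of the chlorine, or to a carboxylic acid in place of the amide.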